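Swapping Chloro for Pentylamino: Expected Cytotoxicity

The source may hold more compounds than are shown below. What is called first, only, known or untested is meant among the compounds shown, and "the series" means these compounds.

Compound 3 `O=C(NCc1ccccc1)c1nccnc1Cl` was examined in an ADME assay on HEL cells (Homo sapiens) for cytotoxicity, read by microscopy, with a stated time of 6 days (on this read-out lower numbers stand for higher toxicity in this test and higher numbers for lower toxicity in this test), but for compound 3 the result is "not determined" (no result reported), so no number stands for it. Two related compounds carry only limits. Compound 1 `CCCCCNc1cnc(C(=O)NCc2ccccc2)cn1` gives in this assay > 100000 nM, a limit of the assay rather than a number. Compound 2 `CCCCNc1cnc(C(=O)NCc2ccccc2)cn1` gives in this assay > 100000 nM, likewise a limit. The step that the two limits leave unreadable from compound 1 to compound 2 cannot be read from two limits, and both rest on (the limit of > 100000 nM in this assay, at which 2 of the 3 values shown sit). Compound 4 `CCCCCNc1nccnc1C(=O)NCc1ccccc1` differs from compound 3 by pentylamino in place of chloro on an aromatic carbon. Among the compounds with values here, no measured step matches this change, and the two limits show only that no toxicity was reached for either. Compound 4 is therefore expected to show a similar absence of toxicity in this assay, with an estimate of 100000 nM and a range from 50000 nM to 200000 nM.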

Compound 4, minimum cytotoxic concentration: >= 100000 nM
Compound 4: a limit, no number; the forecaster's own chance of this, stated with the estimate: 85%; the middle value lies on the limit itself.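

Within the data shown here, compound 4 carries only a limit and compound 3 has no number, so no step between them can be read. The compounds shown leave open the concentration at which compound 1, compound 2 or compound 4 would turn toxic in this assay.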